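Swapping the Sulfonyl Amine Toward Compound 3

The compounds below may be only part of what the source reports. "The series", "measured", "known", "first", "only" and "open" are said of these compounds alone.

Compound 1 `O=C(Nc1ccc(S(=O)(=O)N2CCCCC2)c2ccccc12)c1ccccc1` gives in an assay on L1.2 cells for binding affinity to C-C chemokine receptor type 8 (Homo sapiens) (on this read-out lower numbers stand for stronger inhibition and higher numbers for weaker inhibition), only a limit, > 30000 nM.
Compound 2 `O=C(Nc1ccc(S(=O)(=O)N2CCOCC2)c2ccccc12)c1ccccc1` gives in this assay a value of 7750 nM.

For the measured compounds named here, compound 2 carries the only actual number in this set; the other entry is a limit of the assay, not a measured number. Going by the values given here, the one measured step, an at least 3.8-fold lower number from compound 1 to compound 2 (0.58 log units; beyond the scatter), can be stated only as a lower bound because compound 1 sits at the limit of > 30000 nM in this assay, at which 1 of the 2 values shown sits. Still, it shows that changing the ring attached to the sulfonyl sulfur moves the number by a meaningful amount.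

Compound 3 `CN1CCN(S(=O)(=O)c2ccc(NC(=O)c3ccccc3)c3ccccc23)CC1` makes a change of the same kind at the same place: 4-methylpiperazin-1-yl in place of morpholin-4-yl on a sulfonyl sulfur. Both rings have one hetero atom in the position that, in compound 2, is an oxygen and in compound 3 is a methyl-bearing nitrogen; the step from compound 1 to compound 2 shows this ring matters, but gives no direction for a nitrogen. The expectation is therefore a step near the scatter, a 1.3-fold lower number from compound 2 to compound 3 (0.11 log units; within the scatter), with a wide range. Compound 3 is estimated at 6000 nM, between 1500 nM and 25000 nM.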

Compound 3, inhibition constant: > 30000 nM
Compound 3: a limit, no number; the forecaster's own chance of this, stated with the estimate: 20%; middle value at least 5.0-fold (0.69 log units) from the limit.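

The new result gives an at least 3.8-fold higher number from compound 2 to compound 3 (0.58 log units; beyond the scatter), even though morpholin-4-yl and 4-methylpiperazin-1-yl are both six-membered non-aromatic rings with 2 hetero atoms and the same counts of hydrogen-bond donors and acceptors, so these counts alone do not decide the outcome at this position. This step is only a lower bound, and the step between compound 1 and compound 3 cannot be read, as both compounds give limits rather than numbers. Of the three rings on the sulfonyl sulfur, only morpholin-4-yl, in compound 2, gives a measured number, and the other two compounds stop at the same assay limit: the limit of > 30000 nM in this assay, at which 2 of the 3 values shown sit.

On these data alone, what remains open is how far compound 1 and compound 3 lie beyond that limit, and so whether they differ from each other at all. As far as these compounds go, it is also open whether piperazin-1-yl, which lacks the methyl group, or an open-chain group such as dimethylamino on the sulfonyl sulfur would give a number in this assay.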